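The compounds below may be only part of what the source reports. "The series", "measured", "known", "first", "only" and "open" are said of these compounds alone.

Of the compounds shown here, three sharing one core have been tested in a functional assay on CEM13 cells (Homo sapiens) for cytotoxicity, read by MTT assay, with a stated time of 72 h; on this read-out lower numbers stand for stronger inhibition and higher numbers for weaker inhibition. Compound 1 `Cc1c(C)c2c(c(C)c1OC(=O)CCC(=O)NCC1CC(C)(C)N([O])C1(C)C)CCC(C)(C(=O)NCC1CC(C)(C)N([O])C1(C)C)O2` gives 107000 nM, compound 2 `Cc1c(C)c2c(c(C)c1OC(=O)CCC(=O)NC1CC(C)(C)N([O])C(C)(C)C1)CC[C@@](C)(CCC[C@H](C)CCC[C@H](C)CCCC(C)C)O2` gives 146000 nM, and compound 3 `Cc1c(C)c2c(c(C)c1OC(=O)CCC(=O)O)CCC(C)(C(=O)O)O2` gives 191000 nM. The number for compound 2 is the second highest of the three shown, yet its gaps to compound 3 and to compound 1 both lie within the usual scatter of repeated measurements, so the three cannot be told apart on these numbers. Compound 4 `Cc1c(C)c2c(c(C)c1OC(=O)CCC(=O)NCC1CC(C)(C)N([O])C1(C)C)CC[C@@](C)(CCC[C@H](C)CCC[C@H](C)CCCC(C)C)O2` has not yet been measured. It differs from compound 2 by a group of 11 heavy atoms (9 carbon, 1 nitrogen, 1 oxygen; one five-membered non-aromatic ring with 1 hetero atom) in place of a group of 11 heavy atoms (9 carbon, 1 nitrogen, 1 oxygen; one six-membered non-aromatic ring with 1 hetero atom), on an amide-type nitrogen. Within the data shown here, no measured pair shows a change of this kind, so the expectation rests on the measured numbers sitting close together. The step of a 1.0-fold lower number from compound 2 to compound 4 (0.02 log units; within the scatter) is expected to stay within the scatter. Compound 4 is expected to give about 140000 nM, within a range from 70000 nM to 280000 nM.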

Compound 4, half-maximal inhibitory concentration: 105000 nM
Estimate against measurement, compound 4: 1.3-fold (0.12 log units) above; measured number inside the range.
By their numbers in this assay, from the lowest: compounds 4, 1, 2 and 3 (each within the scatter of the next).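

Putting the five-membered ring in place of the six-membered ring on the amide-type nitrogen gives a 1.4-fold lower number from compound 2 to compound 4 (0.14 log units; within the scatter) in this assay. This first pair at this position shows that, for these two rings, the change cannot be told from the scatter. Nothing available explains the small step. From the compounds shown here alone, whether a group of another kind on this nitrogen, such as a plain butyl chain or a carboxylic acid, would give a step beyond the scatter stays open.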